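Fluoro to Trifluoromethyl: the Expected Maximal Response of Compound 3

A few compounds are considered here, and "the series" means these few. Any claim that something is new, unique, unknown or untested is made for them only; others in the source may bear on it.

The two measured compounds were read in an assay on HEK293 cells for activation of Kir3.1/Kir3.2 (Homo sapiens), read by thallium flux; on this read-out higher numbers stand for larger maximal responses and lower numbers for smaller maximal responses. Compound 1 `Cc1cc(NC(=O)Cn2nnc(-c3ccccc3)n2)n(C2CC2)n1` is reported there only as a limit: in this assay compound 1 gives > 78%, and this value is a limit rather than a number (the limit of > 78% in this assay, at which 1 of the 2 values shown sits). Compound 2 `Cc1cc(NC(=O)Cn2nnc(-c3ccc(F)cc3)n2)n(C2CCCCC2)n1` is the member for which a number is given; in this assay compound 2 gives 92%. Among the values shown, compound 2 therefore carries the only number, and the other value is a limit, which leaves no comparison of the two as numbers.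

Compound 3 `Cc1cc(NC(=O)Cn2nnc(-c3ccc(C(F)(F)F)cc3)n2)n(C2CCCCC2)n1` differs from compound 2 in one place: trifluoromethyl in place of fluoro on an aromatic carbon. Among the measured compounds shown here, no step between two measured compounds is available, and the expectation for compound 3 rests on the number for compound 2 and on the change itself. Compound 3 is expected to make a step of a number 4 percentage points lower from compound 2 to compound 3 (within the scatter) in this assay, no larger than the usual scatter and with no clear direction. In this assay compound 3 is estimated at 88%, with a range from 70% to 105%.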

Compound 3, largest response reached (Emax), in percent of the reference or control that the assay uses: 94%
Compound 3: middle estimate off by 6 percentage points, on the low side, within the range that was stated.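

In this assay, the change from fluoro to trifluoromethyl on an aromatic carbon, para to a large group, gives a number 2 percentage points higher from compound 2 to compound 3 (within the scatter). Among the compounds shown here, this is the first step that can be read between two numbers, as the earlier compounds offered one number and one limit and therefore no step at all. It shows that compound 2 and compound 3 lie within the scatter of each other on this read-out, so the 4-fluorophenyl and 4-(trifluoromethyl)phenyl forms cannot be told apart by maximal response.

From the compounds shown here alone, whether an amine, a carboxylic acid or a nitrile in the same place would also stay within the scatter of compound 2 remains open, as does the outcome of any group on another carbon of that ring. Compound 1 is reported only as a limit and differs from compound 2 in more than one place, so no step involving it can be read, and the part played by its smaller ring on the shared core stays unresolved: the limit of > 78% in this assay, at which 1 of the 3 values shown sits.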